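The source may hold more compounds than are shown below. What is called first, only, known or untested is meant among the compounds shown, and "the series" means these compounds.

Of the compounds shown here, two on the shared core have been measured in an ADME assay on the whole organism for metabolic stability, with Rattus norvegicus as the target; a higher number here means that the compound lasts longer, a lower number that the compound disappears faster. Compound 1 `O=S(=O)(c1ccc(C(F)(F)F)cc1)c1cc(F)c(O)c2ncccc12` gives 3.5 h, and compound 2 `O=S(=O)(c1ccc(F)cc1)c1cc(Cl)c(O)c2ncccc12` gives 8.9 h. Compound 2 thus holds the higher of the two numbers, and its gap to compound 1 lies beyond the usual scatter. The next structure, compound 3 `O=S(=O)(c1ccc(F)cc1)c1cc(F)c(O)c2ncccc12`, departs from compound 2 in one place: fluoro in place of chloro on an aromatic carbon, ortho to a hydroxy group (fluoro in place of chloro on an aromatic carbon). Among the compounds with values here, no two measured compounds differ in one place only, so the data give no direct size for this swap. Within the data shown here, the only guide is compound 1, which also carries fluoro there and stands at 3.5 h. It also bears a trifluoromethyl group that compound 3 lacks, so it can only weakly suggest the direction. A modest fall in this assay is therefore expected, of about the size of the scatter: a 1.8-fold lower number from compound 2 to compound 3 (0.25 log units; within the scatter). For compound 3 the estimated half-life is 5 h, with an expected range from 2.5 h to 10 h.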

Compound 3, half-life: 4.5 h
Estimate against measurement, compound 3: 1.1-fold (0.05 log units) above; measured number inside the range.
By their numbers in this assay, from the lowest: compounds 1, 3 and 2 (each within the scatter of the next, the first and the last beyond it).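

In this assay, the swap of fluoro in place of chloro on an aromatic carbon, ortho to a hydroxy group, now has a direct size: a 2.0-fold lower number from compound 2 to compound 3 (0.30 log units; within the scatter). On this single comparison, the half-life does not separate the two halogens at this position, so the weak hint from compound 1 gains no firm support. The change of fluoro in place of trifluoromethyl on an aromatic carbon also has its first direct size, a 1.3-fold higher number from compound 1 to compound 3 (0.11 log units; within the scatter), so neither single change shown here leaves the scatter, and nothing shown explains the half-lives of these compounds.

Going by these compounds, what remains open is whether a group of a different kind on the aromatic carbon ortho to the hydroxy group, such as an amine, a nitrile or a methoxy group, would move this assay beyond the scatter. Also open, on these data alone, is how a carboxylic acid or a longer chain would behave on the aromatic carbon that bears trifluoromethyl in compound 1 and fluoro in compound 3.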